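The source may report more compounds than this note shows. Statements on the series, on what has been measured and on what is new or still open speak of the compounds shown alone.

compound 1 `O=C1O[C@H]([C@@H](O)Cn2cc(C3CC3)nn2)C(OCc2ccccc2)=C1OCc1ccccc1`: 43900 nM
compound 2 `O=C1O[C@H]([C@@H](O)Cn2cc(-c3cc(F)cc(F)c3)nn2)C(OCc2ccccc2)=C1OCc1ccccc1`: 41200 nM

In a functional assay on A549 cells (Homo sapiens) for antiproliferative activity, read by MTT assay, with a stated time of 72 h (on this read-out lower numbers stand for stronger inhibition and higher numbers for weaker inhibition), compound 2 gives 41200 nM and stands level with compound 1 within the scatter. Compound 3 `O=C1O[C@H]([C@@H](O)Cn2ccnn2)C(OCc2ccccc2)=C1OCc1ccccc1` differs from it by one change hydrogen in place of 3,5-difluorophenyl on an aromatic carbon that puts hydrogen in place of 3,5-difluorophenyl on an aromatic carbon. Among the measured compounds shown here, the only measured step at this place is a 1.1-fold lower number from compound 1 to compound 2 (0.03 log units; within the scatter) and it stayed within the scatter. For the measured compounds named here, no measured compound has hydrogen there, so this expectation is loose. The expected step is a 1.2-fold higher number from compound 2 to compound 3 (0.08 log units; within the scatter) and it remains within the scatter, with no clear direction. In this assay compound 3 is estimated at 50000 nM with a range from 25000 nM to 100000 nM as the likely span.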

Compound 3, half-maximal inhibitory concentration: > 100000 nM
Compound 3: a limit, no number; the forecaster's own chance of this, stated with the estimate: 15%; middle value at least 2.0-fold (0.30 log units) away from the limit.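

Compound 3, with only hydrogen on this aromatic carbon, gives a limit and not a number: the limit of > 100000 nM in this assay, at which 1 of the 3 values shown sits.

Hydrogen in place of 3,5-difluorophenyl gives an at least 2.4-fold higher number from compound 2 to compound 3 (0.38 log units; beyond the scatter), and hydrogen in place of cyclopropyl gives an at least 2.2-fold higher number from compound 1 to compound 3 (0.35 log units; beyond the scatter). So the position is not indifferent: compound 1 and compound 2 stand level despite their very different groups, yet with no group there inhibition is weaker.

Going by these compounds, how far compound 3 really lies from them stays open. So does whether an amine, a carboxylic acid or a longer chain on this carbon would match cyclopropyl.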